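Replacing a Cyclohexyl with an Open Chain on the Aminopyridine

The source may report more compounds than this note shows. Statements on the series, on what has been measured and on what is new or still open speak of the compounds shown alone.

Measured compounds:
- Compound 1 `CSc1nc(-c2ccc(F)cc2)c(-c2ccnc(NC3CCc4ccccc43)c2)[nH]1`: in a functional assay on blood (Homo sapiens) for inhibition (a lower number here means a stronger inhibitor, a higher number a weaker inhibitor), compound 1 gives "not determined" (no result reported)
- Compound 2 `CCC(Nc1cc(-c2[nH]c(SC)nc2-c2ccc(F)cc2)ccn1)c1ccccc1`: in this assay compound 2 gives 7640 nM
- Compound 3 `CSc1nc(-c2ccc(F)cc2)c(-c2ccnc(NC3CCCCC3)c2)[nH]1`: in this assay compound 3 gives "not determined" (no result reported)

Compound 3 stands without a single number in this assay, and compound 1 is the other entry without one. Going by the values given here, the only number available is the one measured for compound 2. All three compounds share the same core and differ only in the group carried on the nitrogen of the aromatic ring.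

The step from compound 3 to compound 4 `CSc1nc(-c2ccc(F)cc2)c(-c2ccnc(NC(C)CCc3ccccc3)c2)[nH]1` is the following change: 1-methyl-3-phenylpropyl in place of cyclohexyl on a nitrogen on an aromatic ring. Among the compounds with values here, no step between two measured compounds is recorded for this change, so its size cannot be read from the series. Compound 2 also carries an open-chain group bearing a phenyl on that nitrogen and gives 7640 nM in this assay, which gives a rough anchor for the open-chain type. For compound 4 the expected outcome in this assay is a weak inhibitor of a similar order, and its estimated value is 5000 nM, with a plausible range from 1500 nM to 15000 nM.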

Compound 4, half-maximal inhibitory concentration: 2370 nM
Compound 4: the middle estimate sits 2.1-fold (0.32 log units) above what was measured; the range from low to high includes it.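

Going by these compounds alone, compound 4 gives the series its second number, and with it the first reading of how this position responds to a change within the open-chain type. In this assay, exchanging 1-phenylpropyl for 1-methyl-3-phenylpropyl on a nitrogen on an aromatic ring gives a 3.2-fold lower number from compound 2 to compound 4 (0.51 log units; beyond the scatter), so the number at this position depends on which phenyl-bearing open chain is attached, although the step is only modest. The comparison with the ring-bearing groups stays closed: the steps from compound 1 and compound 3 cannot be read, since neither compound has a single number in this assay, and nothing shown explains the step between the open chains.

The compounds shown leave open how much of this step belongs to the methyl and how much to the chain that carries the phenyl. They also leave open how this assay would respond to a benzyl group on this nitrogen, or to a longer chain ending in an amine or a carboxylic acid.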